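This account rests on a few compounds, and the source may have more. Where it says the series, first, only, none or still open, it means among the compounds named here.

Measured in a physicochemical assay for lipophilicity, at pH 7.4; a higher number here means a more lipophilic compound, a lower number a more polar compound:
- Compound 1 `COc1ccc2c(=O)cc(C)[nH]c2c1`: 1.2
- Compound 2 `Cc1[nH]c2ccccc2c(=O)c1Cc1ccccc1`: 1.93
- Compound 3 `COc1ccc2c(=O)c(Cc3ccccc3)c(C)[nH]c2c1`: 2.52

Compound 3 stands highest of the three in this assay, at 2.52. Compound 4 `Cc1[nH]c2cc(Cl)ccc2c(=O)c1Cc1ccccc1` differs from it by chloro in place of methoxy on an aromatic carbon. Two measured steps lead to compound 3. The large step of a number 1.32 log units higher from compound 1 to compound 3 (beyond the scatter) comes with benzyl in place of hydrogen, and compound 4 keeps that benzyl, so it says little here. The modest step of a number 0.59 log units higher from compound 2 to compound 3 (beyond the scatter) comes with methoxy in place of hydrogen and bears more directly, since methoxy is the group that leaves. Within the data shown here, no measured step involves chloro, so the expectation is loose. The expected change is small and upward, a number 0.18 log units higher from compound 3 to compound 4 (within the scatter), and is not expected to lie beyond the scatter. For compound 4 the estimated value is 2.7, with an expected range from 2.3 to 3.1.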

Compound 4, distribution coefficient: 2.69
Estimate against measurement, compound 4: 0.01 log units above, within the range that was stated.
By their numbers in this assay, from the lowest: compound 1; then compound 2; then compounds 3 and 4 (each within the scatter of the next).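

On this aromatic carbon, chloro and methoxy cannot be told apart in this assay as the swap gives a number 0.17 log units higher from compound 3 to compound 4 (within the scatter) and no clear change. Chloro in place of hydrogen on the same carbon gives a number 0.76 log units higher from compound 2 to compound 4 (beyond the scatter) and shows that chloro here, like methoxy, moves the number beyond the scatter when compared with hydrogen. No measurement at hand explains why the two groups land so close.

As far as these compounds go, whether an amine or a carboxylic acid on this carbon would shift the number remains open. So does whether chloro would give a similar step on another carbon of the shared core.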